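Replacing aminomethyl with a chlorostyryl group on the shared core

The source may report more compounds than this note shows. Statements on the series, on what has been measured and on what is new or still open speak of the compounds shown alone.

Measured so far in a functional assay on HCT-116 cells (Homo sapiens) for cytotoxicity, read by MTT assay, with a stated time of 72 h; a higher number here means a weaker inhibitor, a lower number a stronger inhibitor:
- compound 1, `[N-]=[N+]=NCc1nnc(-c2cc(S(N)(=O)=O)c(SCc3ccccc3)cc2Cl)o1`, gives 100000 nM
- compound 2, `NS(=O)(=O)c1cc(-c2nnc(Cn3cc(-c4ccccc4)nn3)o2)c(Cl)cc1SCc1ccccc1`, gives 75000 nM
- compound 3, `NCc1nnc(-c2cc(S(N)(=O)=O)c(SCc3ccccc3)cc2Cl)o1`, gives 120000 nM

All three share the same core and differ only in the group hanging from one carbon of the five-membered ring. Compound 3 has the highest of the three numbers, but the steps of a 1.2-fold higher number from compound 1 to compound 3 (0.08 log units; within the scatter) and a 1.6-fold higher number from compound 2 to compound 3 (0.20 log units; within the scatter) both lie within the scatter, so no order among the three can be read from these values.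

Compound 4, `NS(=O)(=O)c1cc(-c2nnc(/C=C/c3cccc(Cl)c3)o2)c(Cl)cc1SCc1ccccc1`, is not yet measured. It differs from compound 3 by the change (2-(3-chlorophenyl)ethenyl in place of aminomethyl on an aromatic carbon).

Among the measured compounds shown here, the steps that bear on this position are the two just named and a 1.3-fold lower number from compound 1 to compound 2 (0.12 log units; within the scatter), which also lies within the scatter; swapping a small azido for a large phenyltriazolyl group moved nothing. By that record, the step to compound 4 is expected to stay within the scatter, a 1.2-fold lower number from compound 3 to compound 4 (0.08 log units; within the scatter), in no particular direction. Compound 4 is therefore expected to give about 100000 nM in this assay, between 40000 nM and 250000 nM.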

Compound 4, half-maximal inhibitory concentration: 12000 nM
For compound 4 the middle estimate is 8.3-fold (0.92 log units) above the measured one; the whole stated range lies above it.
By their numbers in this assay, from the lowest: compound 4; then compounds 2, 1 and 3 (each within the scatter of the next).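

In this assay, this position proves able to move the number after all: the 2-(3-chlorophenyl)ethenyl group gives a 10-fold lower number from compound 3 to compound 4 (1.00 log units; beyond the scatter), along with a 6.3-fold lower number from compound 2 to compound 4 (0.80 log units; beyond the scatter) and an 8.3-fold lower number from compound 1 to compound 4 (0.92 log units; beyond the scatter), whereas the earlier swaps among the other groups stayed within the scatter. Compound 2 also carries a six-membered aromatic ring of carbon only in its group, so the presence of such a ring does not by itself set compound 4 apart. Nothing measured here explains why the number falls with this change.

The change brings in a chlorine, a double bond and a ring together, so the compounds shown leave open which of these matters. A plain 2-phenylethenyl group, with no chlorine, or a saturated 2-(3-chlorophenyl)ethyl chain, would each pull one of these apart from the others.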